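Dichlorobenzyl Analogue of a Pyrrolyl Oxadiazole Series

This account rests on a few compounds, and the source may have more. Where it says the series, first, only, none or still open, it means among the compounds named here.

Measured so far:
Compound 1, `Clc1ccc(-c2nnc(C(NCc3ccccc3)c3ccc[nH]3)o2)cc1`: 41000 nM
Compound 2, `Brc1ccc(-c2nnc(C(NCc3ccccc3)c3ccc[nH]3)o2)cc1`: 70600 nM

In a functional assay on HT-1080 cells (Homo sapiens) for cytotoxicity, read by MTT assay, with a stated time of 24 h (on this read-out lower numbers stand for stronger inhibition and higher numbers for weaker inhibition), compound 1 gives 41000 nM and compound 2 gives 70600 nM. Compound 2 sits alongside compound 1 in this assay: the step of a 1.7-fold higher number from compound 1 to compound 2 (0.24 log units; within the scatter) is within the scatter, so the two measured numbers are not told apart.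

Compound 3, `Clc1ccc(CNC(c2ccc[nH]2)c2nnc(-c3ccc(Br)cc3)o2)cc1Cl`, has yet to be measured. It differs from compound 2 by 3,4-dichlorophenyl in place of phenyl on a saturated chain carbon bound to an amine nitrogen. For the measured compounds named here, no measured step bears on this change: the only step known, from bromo to chloro on the aromatic carbon, touches a different part of the molecule and was itself within the scatter. There is therefore no basis for expecting a shift beyond the scatter in either direction in this assay. Compound 3 is accordingly expected to give about 70000 nM, with a range of 25000 nM to 200000 nM, meaning an estimated step of a 1.0-fold lower number from compound 2 to compound 3 (0.00 log units; within the scatter).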

Compound 3, half-maximal inhibitory concentration: 45300 nM
Beside the measured number, compound 3's estimate is 1.5-fold (0.19 log units) above it; measured number inside the range.
By their numbers in this assay, from the lowest: compounds 1, 3 and 2 (each within the scatter of the next).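

Compound 3 is the first compound shown in which the benzyl group on the amine nitrogen is changed, and in this assay going from benzyl to 3,4-dichlorobenzyl gives a 1.6-fold lower number from compound 2 to compound 3 (0.19 log units; within the scatter) at this position. So 3,4-dichlorophenyl can stand in place of phenyl on a saturated chain carbon bound to an amine nitrogen with no shift that can be told from the scatter, which extends to this second place what the earlier exchange of halogen on the aromatic carbon showed with a 1.7-fold higher number from compound 1 to compound 2 (0.24 log units; within the scatter) in that series. No measurement of any property bears on this result.

The compounds shown leave open whether an amine, a carboxylic acid or a longer chain in place of the benzyl group would move the number beyond the scatter. Also open, as far as these compounds go, is whether 3,4-dichlorobenzyl gives a similar number with chloro in place of bromo on the aromatic carbon.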